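The compounds below may be only part of what the source reports. "The series", "measured", "known", "first", "only" and "open" are said of these compounds alone.

The measured compounds and their values in a functional assay on HCT-116 cells (Homo sapiens) for cytotoxicity, with a stated time of 48 h; on this read-out higher numbers stand for weaker inhibition and lower numbers for stronger inhibition:

Compound 1, `O=[N+]([O-])c1ccc(CN2CCC(n3cc(CC(OCc4cc(-c5ccccc5)no4)c4ccc(Br)cc4)nn3)CC2)cc1`, gives > 25000 nM, which is a limit of the assay rather than a number.
Compound 2, `O=[N+]([O-])c1ccc(CN2CCC(n3cc(CC(OCc4cc(-c5ccc(Br)cc5)no4)c4ccc(Br)cc4)nn3)CC2)cc1`, gives > 25000 nM, again a limit.
Compound 3, `O=[N+]([O-])c1ccc(CN2CCC(n3cc(CC(OCc4cc(-c5ccc(F)cc5)no4)c4ccc(Br)cc4)nn3)CC2)cc1`, gives > 25000 nM, also a limit.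

Compound 3 therefore stands where every value in this set stands: at the limit of > 25000 nM in this assay, at which 3 of the 3 values shown sit. The three measured steps that join these compounds, a step that the two limits leave unreadable from compound 1 to compound 2, a step that the two limits leave unreadable from compound 1 to compound 3 and a step that the two limits leave unreadable from compound 2 to compound 3, all run from one limit to another, so their size cannot be read. Swapping hydrogen, bromo or fluoro on the outer phenyl ring has left no visible trace in this assay.

Compound 4, `COc1ccc(-c2cc(COC(Cc3cn(C4CCN(Cc5ccc([N+](=O)[O-])cc5)CC4)nn3)c3ccc(Br)cc3)on2)cc1`, differs from compound 3 by methoxy in place of fluoro on an aromatic carbon. For the measured compounds named here, no measured step bears on a methoxy group here, and the three steps that do exist are unreadable, so there is no ground to expect a readable change in this assay in either direction; the most likely outcome is again a limit.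

The step from compound 3 to compound 4 is expected to be a step that the limit leaves unreadable from compound 3 to compound 4. Compound 4 is estimated at 30000 nM, with a range from 8000 nM to 120000 nM.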

Compound 4, half-maximal inhibitory concentration: > 25000 nM
Compound 4: no number, only a limit; the forecaster's own chance of this, stated with the estimate: 85%; the middle value does not contradict the limit.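

In this assay compound 4 gives > 25000 nM, which is a limit and not a number. Its steps to compound 1, compound 2 and compound 3 therefore run from limit to limit and cannot be read, and all four compounds now stand at one place: the limit of > 25000 nM in this assay, at which 4 of the 4 values shown sit.

The compounds shown leave open whether hydrogen, bromo, fluoro or methoxy on the outer phenyl ring makes any difference in this assay.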